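A few compounds are considered here, and "the series" means these few. Any claim that something is new, unique, unknown or untested is made for them only; others in the source may bear on it.

Compound 1 `COc1ccc(-n2cnc3cnc(Nc4cccc(NS(C)(=O)=O)c4)cc32)cc1OC`: 6900 nM
Compound 2 `COc1ccc(-n2cnc3cnc(-c4ccccc4C)cc32)cc1OC`: 69 nM
Compound 3 `COc1ccc(-n2cnc3cnc(-c4ccc(F)cc4C)cc32)cc1OC`: 15 nM

In a functional assay on HL-60 cells (Homo sapiens) for activation, read by flow cytometry, with a stated time of 4 days (on this read-out higher numbers stand for an effect only at larger amounts of compound and lower numbers for an effect already at smaller amounts), compound 3 gives 15 nM, the lowest of the three numbers. Compound 4 `COc1ccc(-n2cnc3cnc(-c4cc(F)ccc4OC)cc32)cc1OC` carries 5-fluoro-2-methoxyphenyl in place of 4-fluoro-2-methylphenyl on an aromatic carbon. Among the measured compounds shown here, only one measured step bears on this change: a 4.6-fold lower number from compound 2 to compound 3 (0.66 log units; beyond the scatter). It is modest, lies beyond the scatter, and covers only fluoro in place of hydrogen. For the measured compounds named here, no measured step exchanges the two groups at issue, so the direction remains uncertain. A small step toward a higher number in this assay is expected, no larger than that modest step. The estimate implies a 2.0-fold higher number from compound 3 to compound 4 (0.30 log units; within the scatter), an expected rather than measured change. For compound 4 the estimated value is 30 nM, with an expected range of 7 nM to 130 nM.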

Compound 4, half-maximal effective concentration: 1300 nM
Compound 4: middle estimate off by 43-fold (1.64 log units), on the low side; the measured number lies above the stated range.
By their numbers in this assay, from the lowest: compound 3; then compound 2; then compound 4; then compound 1.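

In this assay, the group on this aromatic carbon next to the ring nitrogen tolerates far less than the fluoro step suggested: 5-fluoro-2-methoxyphenyl in place of 4-fluoro-2-methylphenyl brings an 87-fold higher number from compound 3 to compound 4 (1.94 log units; beyond the scatter), a large step. Against plain 2-methylphenyl the same group brings a 19-fold higher number from compound 2 to compound 4 (1.28 log units; beyond the scatter), so a fluoro on this ring does not by itself secure a low number. Nothing measured here accounts for the change.

The methoxy and the shifted fluoro change together, and the compounds shown do not separate them. Open too, from the compounds shown here alone, is how 4-fluoro-2-methoxyphenyl, or a phenyl ring bearing an amine, would fare here.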